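This account rests on a few compounds, and the source may have more. Where it says the series, first, only, none or still open, it means among the compounds named here.

Compound 1 `CC(C(=O)NCc1ccc(C(F)(F)F)nc1N1CCC(c2ccccc2)CC1)c1ccc(NS(C)(=O)=O)c(F)c1` and compound 2 `C[C@@H](C(=O)NCc1ccc(C(F)(F)F)nc1N1CCC(c2ccccc2)CC1)c1ccc(NS(C)(=O)=O)c(F)c1` are built from the same atoms and bonds; they differ only in that a stereocentre at a saturated chain carbon is drawn without a configuration in compound 1 and R in compound 2. In a functional assay on CHO-K1 cells for antagonist activity at transient receptor potential cation channel subfamily V member 1 (Homo sapiens), read by FLIPR (on this read-out higher numbers stand for weaker inhibition and lower numbers for stronger inhibition), compound 1 gives 25 nM, while compound 2 gives 2350 nM, the highest of the two numbers shown, the gap being a 94-fold higher number from compound 1 to compound 2 (1.97 log units; beyond the scatter). Compound 3 `C[C@H](C(=O)NCc1ccc(C(F)(F)F)nc1N1CCC(c2ccccc2)CC1)c1ccc(NS(C)(=O)=O)c(F)c1` differs from compound 2 in that (the two compounds have the same atoms and bonds and differ only in configuration as drawn: 1 of 1 stereo elements differ; a stereocentre at a saturated chain carbon is drawn R in compound 2 and S in compound 3). Among the measured compounds shown here, the only measured step that bears on this change is a 94-fold higher number from compound 1 to compound 2 (1.97 log units; beyond the scatter); because the fact that one of compounds 1 and 2 is drawn with a defined configuration and the other without, at the place where they differ compound 1 is best read as a mixture of both forms, so its stronger inhibition should come from the form that is not compound 2. A step of a 180-fold lower number from compound 2 to compound 3 (2.26 log units; beyond the scatter) towards stronger inhibition is therefore expected in this assay. Compound 3 is estimated at 13 nM, within a range from 5 nM to 40 nM.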

Compound 3, half-maximal inhibitory concentration: 17.4 nM
The estimate for compound 3 lay 1.3-fold (0.13 log units) below the measured number, within the range that was stated.
By their numbers in this assay, from the lowest: compounds 3 and 1 (each within the scatter of the next); then compound 2.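

The S form at this chain carbon carries the inhibition in this assay, and the R form keeps little of it, with a 140-fold lower number from compound 2 to compound 3 (2.13 log units; beyond the scatter) as a large change in which no atom enters or leaves. This step can be tied to the arrangement in space at this one carbon alone: the fact that compounds 2 and 3 differ only in the configuration as drawn. Compound 1 and compound 3 cannot be told apart in this assay, with a 1.4-fold lower number from compound 1 to compound 3 (0.16 log units; within the scatter) lying within the scatter, so the undefined drawing gives no inhibition that the S form does not also give: the fact that one of compounds 1 and 3 is drawn with a defined configuration and the other without, at the place where they differ.

The compounds shown leave open whether S remains the better form when an ethyl group or a hydroxyl group takes the place of the methyl group on this carbon. They also do not show why the two forms differ so widely.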